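From a biaryl anilide to a naphthyl anilide

This account rests on a few compounds, and the source may have more. Where it says the series, first, only, none or still open, it means among the compounds named here.

Compound 1, `C[C@H](NC(=O)C(=O)NC1CCCCC1)C(=O)N[C@@H](CC(=O)O)C(=O)COc1c(F)c(F)cc(F)c1F`: in a functional assay on THP-1 cells (Homo sapiens) for inhibition (on this read-out lower numbers stand for stronger inhibition and higher numbers for weaker inhibition), compound 1 gives 500 nM.
Compound 2, `C[C@H](NC(=O)C(=O)Nc1ccccc1-c1ccc[nH]1)C(=O)N[C@@H](CC(=O)O)C(=O)COc1c(F)c(F)cc(F)c1F`: in this assay compound 2 reaches only > 32000 nM, which is a limit of the assay and not a number.

Compound 2 therefore stands at the limit of > 32000 nM in this assay, at which 1 of the 2 values shown sits; of the two measured compounds only compound 1 has a number. Among the measured compounds shown here, the one measured step, an at least 64-fold higher number from compound 1 to compound 2 (1.80 log units; beyond the scatter), came with 2-(1H-pyrrol-2-yl)phenyl in place of cyclohexyl on an amide-type nitrogen. Compound 3, `C[C@H](NC(=O)C(=O)Nc1cccc2ccccc12)C(=O)N[C@@H](CC(=O)O)C(=O)COc1c(F)c(F)cc(F)c1F`, follows from compound 2 by naphthalen-1-yl in place of 2-(1H-pyrrol-2-yl)phenyl on an amide-type nitrogen. For the measured compounds named here, this exchanges one aryl group for another on the same nitrogen, whereas the only measured step exchanged a cyclohexyl for an aryl group, so no measured step bears directly on it. With compound 2 already at the limit, the expected outcome is a number near that limit, that is an at least 1.6-fold lower number from compound 2 to compound 3 (0.20 log units; that floor lies within the scatter) in this assay, nothing beyond the scatter. Compound 3 is therefore estimated at 20000 nM, within a range from 4000 nM to 100000 nM, and may well be reported as a limit again.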

Compound 3, half-maximal inhibitory concentration: 60 nM
Compound 3: the middle estimate sits 330-fold (2.52 log units) above what was measured; measured number outside the range, below it.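

Naphthalen-1-yl in place of 2-(1H-pyrrol-2-yl)phenyl on the amide-type nitrogen brings an at least 530-fold lower number from compound 2 to compound 3 (2.72 log units; beyond the scatter) in this assay, so an aryl group on this nitrogen can go with strong inhibition, and the loss seen with compound 2 does not extend to aryl groups as such. Naphthalen-1-yl also compares favourably with the original group, with an 8.3-fold lower number from compound 1 to compound 3 (0.92 log units; beyond the scatter), so the earlier drop on moving from cyclohexyl to an aryl group holds for compound 2 and is reversed by compound 3. The step from the pyrrole-bearing anilide gives only a floor, and the value of compound 2 is a limit of the assay and not a number: the limit of > 32000 nM in this assay, at which 1 of the 3 values shown sits.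

The compounds shown leave open whether the difference rests on the pyrrole ring or on the second six-membered aromatic ring, which a plain phenyl, a naphthalen-2-yl or a 2-(furan-2-yl)phenyl on the same nitrogen could help to separate. They also leave open whether naphthalen-1-yl keeps its lead over cyclohexyl when the methyl group of the shared core gives way to a longer chain.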